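A few compounds are considered here, and "the series" means these few. Any claim that something is new, unique, unknown or untested is made for them only; others in the source may bear on it.

Measured in an ADME assay on THP-1 cells (Homo sapiens) for cytotoxicity, read by flow cytometry and propidium iodide staining, with a stated time of 72 h; on this read-out lower numbers stand for stronger inhibition and higher numbers for weaker inhibition:
- Compound 1 `CC(=O)Nc1ccc2oc(-c3cccc(C(F)(F)F)c3)cc(=O)c2c1`: 50000 nM
- Compound 2 `Nc1ccc2oc(-c3cccc(F)c3)cc(=O)c2c1`: > 125000 nM

Compound 2 has no numerical reading in this assay, only a limit of the assay, > 125000 nM. Compound 3 `Nc1ccc2oc(-c3cccc(C(F)(F)F)c3)cc(=O)c2c1` carries trifluoromethyl in place of fluoro on an aromatic carbon, meta to a large group (trifluoromethyl in place of fluoro on an aromatic carbon). Among the compounds with values here, no measured step shows this change directly. Compound 1, which also bears trifluoromethyl, gives 50000 nM, and this points to a modest gain. The expected change is an at least 1.7-fold lower number from compound 2 to compound 3 (0.25 log units; that floor lies within the scatter), a modest step towards stronger inhibition. For compound 3 the estimated value is 70000 nM, with an expected range of 25000 nM to 125000 nM.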

Compound 3, half-maximal inhibitory concentration: 34000 nM
Beside the measured number, compound 3's estimate is 2.1-fold (0.31 log units) above it, within the range that was stated.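

In this assay, within the data shown here, trifluoromethyl in place of fluoro on an aromatic carbon, meta to a large group, gives an at least 3.6-fold lower number from compound 2 to compound 3 (0.56 log units; beyond the scatter) and so has a direct reading for the first time. Compound 2 holds only a limit of the assay, so this step is a floor and not a full size: the limit of > 125000 nM in this assay, at which 1 of the 3 values shown sits. Hydrogen in place of acetyl on a nitrogen on an aromatic ring gives a 1.5-fold lower number from compound 1 to compound 3 (0.17 log units; within the scatter), so the acetyl shows no readable difference here. The compounds shown leave open how chloro, methoxy or a nitrile would read in place of trifluoromethyl. They also leave open whether a longer chain on the nitrogen would read differently from acetyl.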